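Methoxy to phenyl on the shared core

The source may report more compounds than this note shows. Statements on the series, on what has been measured and on what is new or still open speak of the compounds shown alone.

Compound 1 `CS(=O)(=O)c1coc(C(=O)CCCCCCc2ccccc2)n1` gives 389 nM in an assay on HEK-293T cells for inhibition of diacylglycerol lipase-alpha (Homo sapiens), read by colorimetric assay; a lower number here means a stronger inhibitor, a higher number a weaker inhibitor.
Compound 2 `CN(C)C(=O)c1coc(C(=O)CCCCCCc2ccccc2)n1` gives 3390 nM in this assay.
Compound 3 `COc1coc(C(=O)CCCCCCc2ccccc2)n1` is reported only as a limit, > 10000 nM in this assay.

Compound 3 therefore stands at the limit of > 10000 nM in this assay, at which 1 of the 3 values shown sits, and is the only one of the three without a number. The step of an at least 25-fold higher number from compound 1 to compound 3 (1.41 log units; beyond the scatter) and the step of an at least 2.9-fold higher number from compound 2 to compound 3 (0.46 log units; beyond the scatter) both run up to that limit; the step of an 8.7-fold higher number from compound 1 to compound 2 (0.94 log units; beyond the scatter) lies between the two numbered compounds.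

The next compound, compound 4 `O=C(CCCCCCc1ccccc1)c1nc(-c2ccccc2)co1`, differs from compound 3 by phenyl in place of methoxy on an aromatic carbon. Within the data shown here, none of the measured steps introduces a phenyl, so no step bears on it directly; the measured steps show only that methylsulfonyl and dimethylcarbamoyl at this position give lower numbers than methoxy, and that methoxy sits at the limit. Because compound 3 gives > 10000 nM, the step to compound 4 can only be estimated downward or flat, and the estimate is wide. Compound 4 is expected at 2500 nM, within 500 nM to 10000 nM, which means an expected step of an at least 4.0-fold lower number from compound 3 to compound 4 (0.60 log units; beyond the scatter).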

Compound 4, half-maximal inhibitory concentration: 8710 nM
Compound 4: the middle estimate sits 3.5-fold (0.54 log units) below what was measured; the measured number falls inside the stated range.
By their numbers in this assay, from the lowest: compound 1; then compound 2; then compound 4. At a limit, above all of these: compound 3.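

In this assay, phenyl on this aromatic carbon, next to the ring nitrogen, gives a higher number than dimethylcarbamoyl (a 2.6-fold higher number from compound 2 to compound 4 (0.41 log units; beyond the scatter)) and a much higher number than methylsulfonyl (a 22-fold higher number from compound 1 to compound 4 (1.35 log units; beyond the scatter)). Among the groups with a number at this position, the order from the lowest is therefore methylsulfonyl, dimethylcarbamoyl, phenyl, so the added aromatic ring and its extra heavy atoms do not bring the number close to that of compound 1. Compound 3 remains a limit rather than a number, so the step with methoxy leaving and phenyl entering reads only as an at least 1.1-fold lower number from compound 3 to compound 4 (0.05 log units; that floor lies within the scatter), and methoxy and phenyl cannot be ordered: the limit of > 10000 nM in this assay, at which 1 of the 4 values shown sits.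

A carboxylic acid, a primary amide or an amine at this position could show whether the order extends beyond these groups. From the compounds shown here alone, a pyridine ring or a phenyl carrying a methylsulfonyl group also remains open, as a test of whether an aromatic ring here can reach the number of compound 1.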